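The source may report more compounds than this note shows. Statements on the series, on what has been measured and on what is new or still open speak of the compounds shown alone.

Measured in a functional assay on EBC-1 cells (Homo sapiens) for antiproliferative activity, read by sulforhodamine B assay, with a stated time of 72 h; on this read-out lower numbers stand for stronger inhibition and higher numbers for weaker inhibition:
- compound 1 `Cn1cc(-c2ccc(=O)n(CCOc3ccnc4cc(OCCCCC(=O)NO)ccc34)n2)cn1`: 370 nM
- compound 2 `Cn1cc(-c2ccc(=O)n(CCOc3ccnc4cc(OCc5ccc(CCC(=O)Nc6ccccc6N)cc5)ccc34)n2)cn1`: 210 nM
- compound 3 `Cn1cc(-c2ccc(=O)n(CCOc3ccnc4cc(OCCCOc5ccc(C(=O)Nc6ccccc6N)nc5)ccc34)n2)cn1`: 58 nM

Compound 1 has the highest number of the three at 370 nM, although compound 2 lies within the scatter of it. Only compound 3 stands clearly lower, beyond the scatter.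

The next compound to be tested is compound 4 `Cn1cc(-c2ccc(=O)n(CCOc3ccnc4cc(C(=O)Nc5ccccc5N)ccc34)n2)cn1`. It differs from compound 1 at a single place, on an aromatic carbon of the core: (2-aminophenyl)carbamoyl in place of 4-(hydroxycarbamoyl)butoxy on an aromatic carbon. In words, (2-aminophenyl)carbamoyl stands in place of 4-(hydroxycarbamoyl)butoxy.

Within the data shown here, no measured pair isolates a change of this kind, so any expectation in this assay rests on indirect evidence. Compound 2, at 210 nM, and compound 3, at 58 nM, both carry the (2-aminophenyl)carbamoyl group, but each has it joined to the core through a linker that compound 4 lacks. That gap leaves the forecast uncertain, so only a modest lowering is expected, and a step within the scatter would be no surprise. The expected step is a 2.3-fold lower number from compound 1 to compound 4 (0.36 log units; beyond the scatter).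

For compound 4 the estimated value is 160 nM, with an expected range of 40 nM to 600 nM.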

Compound 4, half-maximal inhibitory concentration: > 10000 nM
Compound 4 ended at the assay's limit; the forecaster's own chance of this, stated with the estimate: 3%; at least 62-fold (1.79 log units) between middle value and limit.
By their numbers in this assay, from the lowest: compound 3; then compounds 2 and 1 (each within the scatter of the next). At a limit, above all of these: compound 4.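

In this assay compound 4 gives a limit of the assay and not a number, and it is the only one of the compounds shown to do so: the limit of > 10000 nM in this assay, at which 1 of the 4 values shown sits. Read as a limit, replacing 4-(hydroxycarbamoyl)butoxy with (2-aminophenyl)carbamoyl on this aromatic carbon of the core is a large step, an at least 27-fold higher number from compound 1 to compound 4 (1.43 log units; beyond the scatter). The earlier compounds shown here carried the (2-aminophenyl)carbamoyl group only at the end of a linker, so compound 4 adds a new finding: set directly on this carbon, the group gives no value short of the limit.

The change removes the butoxy chain and the hydroxycarbamoyl end together, so the step cannot be assigned to either part alone. On these data alone, it remains open whether a butoxy chain ending in a carboxylic acid, or a simple amine on this same aromatic carbon, would give a value short of the limit.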